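Extending the sulfur substituent of compound 3

The source may report more compounds than this note shows. Statements on the series, on what has been measured and on what is new or still open speak of the compounds shown alone.

In a functional assay on HT cells (Homo sapiens) for antiproliferative activity, read by fluorescence, with a stated time of 72 h (a higher number here means a weaker inhibitor of growth, a lower number a stronger inhibitor of growth), compound 3 `CSc1nc(NCc2ccc(-c3ccccn3)cc2)c2[nH]nc(C(C)C)c2n1` gives 783 nM. That value is within the scatter of compound 2 `CC(C)c1n[nH]c2c(NCc3ccc(-c4ccccn4)cc3)nc(SC(CO)C(C)C)nc12` at 980 nM, while compound 1 `CC(C)c1n[nH]c2c(NCc3ccc(-c4ccccn4)cc3)nc(SCC3CNC(=O)O3)nc12`, at 80 nM, stands clearly apart on the stronger side.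

Compound 4 `CC(C)c1n[nH]c2c(NCc3ccc(-c4ccccn4)cc3)nc(SCCCN(C)C)nc12` has 2-(dimethylamino)ethyl in place of hydrogen on a saturated chain carbon bound to a sulfur.

Among the compounds with values here, two measured steps bear on this change. The large-sized a 9.8-fold higher number from compound 1 to compound 3 (0.99 log units; beyond the scatter) lies beyond the scatter, whereas a 1.3-fold lower number from compound 2 to compound 3 (0.10 log units; within the scatter) lies within it. Neither involves the entering group, so the evidence is split.

A modest move towards stronger growth inhibition is expected, with an estimated 2.4-fold lower number from compound 3 to compound 4 (0.39 log units; beyond the scatter). For compound 4 the expected value is 320 nM, with an estimated range of 90 nM to 1100 nM.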

Compound 4, concentration for 50% growth inhibition: 105 nM
Compound 4: the middle estimate sits 3.0-fold (0.48 log units) above what was measured; the range from low to high includes it.
By their numbers in this assay, from the lowest: compounds 1 and 4 (each within the scatter of the next); then compounds 3 and 2 (each within the scatter of the next).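

In this assay the open-chain 3-(dimethylamino)propyl on the sulfur brings a 7.5-fold lower number from compound 3 to compound 4 (0.87 log units; beyond the scatter) and a 9.3-fold lower number from compound 2 to compound 4 (0.97 log units; beyond the scatter) so extending this substituent can pay, though the open chain of compound 2 shows no such gain over compound 3. The 2-oxo-1,3-oxazolidin-5-yl ring is not needed for the stronger level, as a 1.3-fold higher number from compound 1 to compound 4 (0.12 log units; within the scatter) shows. No measurement here accounts for these steps.

Going by these compounds, whether the step depends on the amine nitrogen or on chain length stays open. A plain butyl chain, a primary amine or a longer aminoalkyl chain on the sulfur would separate these.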